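Extending the Amide Substituent: Expected Cytotoxicity of Compound 3

The compounds below may be only part of what the source reports. "The series", "measured", "known", "first", "only" and "open" are said of these compounds alone.

For the measured compounds named here, compound 1 `Cc1cn([C@@H]2O[C@H](CO[Si](C)(C)C(C)(C)C)[C@@]3(OS(=O)(=O)C=C3NC(N)=O)[C@H]2O[Si](C)(C)C(C)(C)C)c(=O)n(C)c1=O` is the lower of the two numbers measured so far in a functional assay on MT4 cells (Homo sapiens) (on this read-out lower numbers stand for higher toxicity in this test and higher numbers for lower toxicity in this test), where compound 1 gives 3700 nM. Its nearest neighbour is compound 2 `Cc1cn([C@@H]2O[C@H](CO[Si](C)(C)C(C)(C)C)[C@@]3(OS(=O)(=O)C=C3NC(=O)c3ccccc3)[C@H]2O[Si](C)(C)C(C)(C)C)c(=O)n(C)c1=O`, which in this assay gives 4900 nM; the step of a 1.3-fold higher number from compound 1 to compound 2 (0.12 log units; within the scatter) is phenyl in place of amino on a carbonyl carbon and lies within the scatter. Compound 3 `Cc1cn([C@@H]2O[C@H](CO[Si](C)(C)C(C)(C)C)[C@@]3(OS(=O)(=O)C=C3NCC(=O)C(N)=O)[C@H]2O[Si](C)(C)C(C)(C)C)c(=O)n(C)c1=O` differs from compound 1 as follows: (carbamoylcarbonyl)methyl in place of carbamoyl on an amine nitrogen. Going by the values given here, only the step from compound 1 to compound 2 bears on this change, and only loosely, since it alters the group on the carbonyl carbon rather than lengthening the chain on the amine nitrogen; it showed no movement beyond the scatter. No step beyond the scatter is therefore expected in this assay for compound 3. The estimated step is a 1.1-fold higher number from compound 1 to compound 3 (0.03 log units; within the scatter). Compound 3 is expected to give 4000 nM, with a range from 1800 nM to 9000 nM.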

Compound 3, half-maximal cytotoxic concentration: 9590 nM
Compound 3: the middle estimate sits 2.4-fold (0.38 log units) below what was measured; the whole stated range lies below it.
By their numbers in this assay, from the lowest: compounds 1, 2 and 3 (each within the scatter of the next, the first and the last beyond it).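

In this assay, for the compounds shown here, the amine nitrogen proves able to register a change: (carbamoylcarbonyl)methyl in place of carbamoyl gives the first step in this set to pass beyond the scatter, though only a modest one (a 2.6-fold higher number from compound 1 to compound 3 (0.41 log units; beyond the scatter)). Measured against benzoyl, the same group gives a step that stays within the scatter (a 2.0-fold higher number from compound 2 to compound 3 (0.29 log units; within the scatter)), so the change separates clearly only from the carbamoyl group of compound 1. Nothing shown here accounts for this step.

The compounds shown leave open whether the step follows from the longer chain on the nitrogen or from the carbonyl inside it. They also leave open whether a carboxylic acid in place of the terminal carbamoyl, or a longer chain ending in an amine, would move the number further.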